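The source may report more compounds than this note shows. Statements on the series, on what has been measured and on what is new or still open speak of the compounds shown alone.

Measured so far in a functional assay on SW480 cells (Homo sapiens) for antiproliferative activity, read by MTT assay, with a stated time of 48 h; a lower number here means a stronger inhibitor, a higher number a weaker inhibitor:
- compound 1 `CCCCC(CCO)n1cnc2c(OC)ncnc21`: > 50000 nM
- compound 2 `CCCCCCC(CCO)n1cnc2c(OC)ncnc21`: > 50000 nM
- compound 3 `CCCCCCC(CCO)n1cnc2c(N(C)C)ncnc21`: > 50000 nM

Compound 2 stands at > 50000 nM, which is a limit of the assay and not a number. The whole series sits at the limit of > 50000 nM in this assay, at which 3 of the 3 values shown sit.

Compound 4 `CCCCCCCC(CCO)n1cnc2c(OC)ncnc21` differs from compound 2 by one small change: methyl in place of hydrogen on a saturated chain carbon, seven bonds along the chain from an aromatic nitrogen. Within the data shown here, the closest precedent is a step that the two limits leave unreadable from compound 1 to compound 2, where the chain also grew, with ethyl in place of hydrogen. The other measured change, a step that the two limits leave unreadable from compound 2 to compound 3, concerns a different part of the molecule, with dimethylamino in place of methoxy on an aromatic carbon, so it bears less on this question.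

Neither precedent gives a size, so no step beyond the usual scatter is expected in this assay, and no direction can be favoured. The estimate therefore means an expected step of a number no higher from compound 2 to compound 4 (the limit leaves the size open). For compound 4 the expected value is about 50000 nM, with an estimated range of 20000 nM to 100000 nM.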

Compound 4, half-maximal inhibitory concentration: 23900 nM
Compound 4: the middle estimate sits 2.1-fold (0.32 log units) above what was measured, within the range that was stated.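

In this assay, among these compounds, compound 4 is the first to give a readable number, which shows that this part of the chain can affect the result. A methyl added to the chain gives an at least 2.0-fold lower number from compound 2 to compound 4 (0.32 log units; beyond the scatter), and propyl in place of hydrogen, five bonds along the chain, gives an at least 2.0-fold lower number from compound 1 to compound 4 (0.32 log units; beyond the scatter). The earlier steps cannot be read, and the full size of these two stays open, since each starts from a limit: the limit of > 50000 nM in this assay, at which 3 of the 4 values shown sit.

As far as these compounds go, whether a longer chain would lower the number further remains open. From the compounds shown here alone, it is also open whether dimethylamino in place of methoxy on an aromatic carbon, or an amine in place of the chain's hydroxyl, would keep this activity.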